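This account rests on a few compounds, and the source may have more. Where it says the series, first, only, none or still open, it means among the compounds named here.

Measured in a physicochemical assay for solubility, read by HPLC, at pH 6.8; on this read-out lower numbers stand for lower solubility and higher numbers for higher solubility:
- Compound 1 `Cn1cc(C(=O)Nc2ccc3[nH]ncc3c2)c2ncc(-c3ccccc3)cc21`: 60 ug/mL
- Compound 2 `CCn1cc(C(=O)Nc2ccc3[nH]ncc3c2)c2ncc(-c3ccccc3)cc21`: < 60 ug/mL

Compound 2 has no exact number on this scale. It sits at the limit of < 60 ug/mL in this assay, at which 1 of the 2 values shown sits, and that reading is a limit.

Compound 3 `CC(C)n1cc(C(=O)Nc2ccc3[nH]ncc3c2)c2ncc(-c3ccccc3)cc21` is not yet measured. It differs from compound 2 by a single change, ethyl to isopropyl (methyl in place of hydrogen on a saturated chain carbon bound to an aromatic nitrogen and a saturated chain carbon). This places methyl in place of hydrogen on a saturated chain carbon bound to an aromatic nitrogen and a saturated chain carbon.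

Among the measured compounds shown here, only one measured step bears on this, a similar exchange of hydrogen for methyl: a number no higher from compound 1 to compound 2 (the limit leaves the size open). Its direction is readable, but its size is not. Going by a number no higher from compound 1 to compound 2 (the limit leaves the size open), a modest step down in this assay is expected, possibly none beyond the scatter. The expected step is a step that the limit leaves unreadable from compound 2 to compound 3. The reading could well be another limit rather than a number. The estimate for compound 3 is 30 ug/mL, with an expected range of 8 ug/mL to 60 ug/mL.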

Compound 3, solubility: 3200 ug/mL
Estimate against measurement, compound 3: 110-fold (2.03 log units) below; measured number outside the range, above it.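

In this assay, exchanging hydrogen for methyl on a saturated chain carbon bound to an aromatic nitrogen and a saturated chain carbon gives an at least 53-fold higher number from compound 2 to compound 3 (1.72 log units; beyond the scatter), whereas the similar exchange on a saturated chain carbon bound to an aromatic nitrogen gave a number no higher from compound 1 to compound 2 (the limit leaves the size open), so the same small addition does not point the same way at these two places. Comparing the two exact numbers, isopropyl in place of methyl on the aromatic nitrogen gives a 53-fold higher number from compound 1 to compound 3 (1.73 log units; beyond the scatter), which fixes the size of the gain without relying on a limit. Compound 2 itself has only a limit on this scale: the limit of < 60 ug/mL in this assay, at which 1 of the 3 values shown sits.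

The compounds shown cannot tell whether the high reading belongs to isopropyl alone. A cyclopropyl ring, a tert-butyl group or a straight propyl chain on the same nitrogen could read like compound 3 or like compound 2.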